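Aryl sulfonyl variation on the shared core: notes

The source may report more compounds than this note shows. Statements on the series, on what has been measured and on what is new or still open speak of the compounds shown alone.

Measured so far:
compound 1, `Cc1ccc(S(=O)(=O)c2cnc3cc(Cl)ccc3c2N2CCC(C)CC2)cc1C`: 86%
compound 2, `COc1ccc(S(=O)(=O)c2cnc3cc(Cl)ccc3c2N2CCC(C)CC2)cc1OC`: 93%

In an assay on isolated protein for displacement of a labelled ligand from metabotropic glutamate receptor 5 (Homo sapiens), with a stated time of 60 min, tested at 1 uM (a lower number here means less inhibition, a higher number more inhibition at the concentration tested (going by the name of the read-out)), compound 2 gives 93%. Going by the values given here, its only neighbour is compound 1, and the step of a number 7 percentage points higher from compound 1 to compound 2 (within the scatter) lies within the scatter, so the two numbers cannot be ordered.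

Compound 3, `CC1CCN(c2c(S(=O)(=O)c3ccc(F)c(Cl)c3)cnc3cc(Cl)ccc23)CC1`, is not yet measured. It differs from compound 2 as follows: 3-chloro-4-fluorophenyl in place of 3,4-dimethoxyphenyl on a sulfonyl sulfur. Among the compounds with values here, the one step that bears on this position, a number 7 percentage points higher from compound 1 to compound 2 (within the scatter), was within the scatter, and no step to a halogenated phenyl is on record. No step beyond the scatter is therefore expected in this assay; the estimated step is a number 8 percentage points lower from compound 2 to compound 3 (within the scatter). Compound 3 is expected to give 85%, with a range of 65% to 98%.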

Compound 3, a percentage reported as inhibition, at one concentration (the size of the read-out at that concentration, not a potency): 94%
The estimate for compound 3 lay 9 percentage points below the measured number; low and high end bracket the measured number.
By their numbers in this assay, from the lowest: compounds 1, 2 and 3 (each within the scatter of the next).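

In this assay, a halogenated phenyl on the sulfonyl sulfur can now be compared, and neither a number 1 percentage points higher from compound 2 to compound 3 (within the scatter) nor a number 8 percentage points higher from compound 1 to compound 3 (within the scatter) separates 3-chloro-4-fluorophenyl from the other two aryl groups. Losing the hydrogen-bond acceptors of 3,4-dimethoxyphenyl therefore gives no step beyond the scatter. Nothing on hand explains why these groups read alike.

Still open, as far as these compounds go, is whether a basic amine or carboxylic acid on the phenyl, or a plain alkyl chain replacing it, would give a step beyond the scatter. A single-concentration read-out also leaves any potency differences among these three compounds unresolved.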